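Swapping nitro for fluoro on a phenyl ether

A few compounds are considered here, and "the series" means these few. Any claim that something is new, unique, unknown or untested is made for them only; others in the source may bear on it.

Two compounds share one core: compound 1 `CN(C)C(=O)n1ccc(-c2ccc(Oc3ccc(F)cc3)cc2)n1` and compound 2 `NC(=O)n1ccc(-c2ccc(Oc3ccc([N+](=O)[O-])cc3)cc2)n1`. In an assay on HEK293 cells for binding affinity to sodium channel protein type 4 subunit alpha (Homo sapiens) (a higher number here means a weaker inhibitor, a lower number a stronger inhibitor), compound 1 gives 340 nM, whereas compound 2 gives 31 nM, the lower of the two numbers and therefore the stronger inhibitor. The two differ in two places at once, so the numbers alone cannot tell which change matters.

Compound 3 `NC(=O)n1ccc(-c2ccc(Oc3ccc(F)cc3)cc2)n1` keeps everything of compound 2 except one group: fluoro in place of nitro on an aromatic carbon. Among the measured compounds shown here, with only two measured compounds and no single-change comparison available, the step is uncertain; compound 1 carries the same fluoro group yet a different amide, so its weaker number offers only a loose hint. A moderate weakening is expected, with the step from compound 2 to compound 3 estimated at a 3.9-fold higher number from compound 2 to compound 3 (0.59 log units; beyond the scatter) in this assay. For compound 3 the expected value in this assay is 120 nM, within a range from 40 nM to 400 nM.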

Compound 3, inhibition constant: 31 nM
Beside the measured number, compound 3's estimate is 3.9-fold (0.59 log units) above it; measured number below the stated range.
By their numbers in this assay, from the lowest: compounds 2 and 3 (each within the scatter of the next); then compound 1.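

In this assay, fluoro in place of nitro on an aromatic carbon, para to a large group, gives no change at the digits printed from compound 2 to compound 3 (within the scatter), so at this position the two groups cannot be told apart by this read-out. The large gap lies at the other end of the molecule: amino in place of dimethylamino on a carbonyl carbon gives an 11-fold lower number from compound 1 to compound 3 (1.04 log units; beyond the scatter), a single change that accounts for a big shift in the number. Nothing available explains why one change matters and the other does not.

As far as these compounds go, whether a quite different group on that aromatic carbon, such as methoxy, nitrile or an amine, would also leave the number in place remains open. So does the effect of methylamino on the carbonyl carbon, which would sit between the amino and dimethylamino groups compared here.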